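The source may report more compounds than this note shows. Statements on the series, on what has been measured and on what is new or still open speak of the compounds shown alone.

Compounds measured in a functional assay on A549 cells (Homo sapiens) for antiproliferative activity, read by MTT assay; on this read-out higher numbers stand for weaker inhibition and lower numbers for stronger inhibition:
compound 1 `Cn1c(=O)c(=O)n(C2CCCC2)c2nc(N/N=C/c3cccs3)ncc21`
compound 2 `COc1ccc(/C=N/Nc2ncc3c(n2)n(C2CCCC2)c(=O)c(=O)n3C)c(OC)c1`

In this assay compound 1 gives > 100000 nM, which is a limit of the assay and not a number. Compound 2 gives > 100000 nM, likewise a limit. The step from compound 1 to compound 2 is thus a step that the two limits leave unreadable from compound 1 to compound 2; both values sit at the limit of > 100000 nM in this assay, at which 2 of the 2 values shown sit. Compound 3 `Cn1c(=O)c(=O)n(C2CCCC2)c2nc(N/N=C/c3cc([N+](=O)[O-])ccc3Cl)ncc21` differs from compound 2 in that (2-chloro-5-nitrophenyl in place of 2,4-dimethoxyphenyl on a carbon with a double bond to nitrogen). Within the data shown here, the only measured step bears on this change, but with both ends at limits its size and direction cannot be read. Compound 3 is therefore expected to remain at the limit, giving a step that the limit leaves unreadable from compound 2 to compound 3. Compound 3 is estimated at 150000 nM, with a range from 40000 nM to 600000 nM.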

Compound 3, half-maximal inhibitory concentration: 8780 nM
Compound 3: the middle estimate sits 17-fold (1.23 log units) above what was measured; measured number below the stated range.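

Attaching 2-chloro-5-nitrophenyl to the carbon with a double bond to nitrogen gives the first readable change at this position in this assay: an at least 11-fold lower number from compound 2 to compound 3 (1.05 log units; beyond the scatter) and an at least 11-fold lower number from compound 1 to compound 3 (1.05 log units; beyond the scatter). Both steps are bounded only on one side, and the step between compound 1 and compound 2 cannot be read: the limit of > 100000 nM in this assay, at which 2 of the 3 values shown sit. The 2,4-dimethoxyphenyl and 2-chloro-5-nitrophenyl groups match in heavy atoms and hydrogen-bond acceptors, so those counts do not track the step.

Still open, going by these compounds, is whether chlorine or the nitro group carries the step. A phenyl bearing only one of them, or an amine in place of the nitro group, would separate the two.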